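Extending the hydroxycarbamoyl chain of compound 3

The source may report more compounds than this note shows. Statements on the series, on what has been measured and on what is new or still open speak of the compounds shown alone.

In a functional assay on HL-60 cells (Homo sapiens) for antiproliferative activity, read by MTT assay, with a stated time of 48 h (on this read-out lower numbers stand for stronger inhibition and higher numbers for weaker inhibition), compound 1 (`O=C(CCCCCC(=O)Nc1ccc(O)c(C(=O)Nc2ccc(F)c(Cl)c2)c1)NO`) gives > 100000 nM as a limit, not a number. Compound 2 (`O=C(CCCCCC(=O)Nc1ccc(O)c(C(=O)Nc2cccc(C(F)(F)F)c2)c1)NO`) gives > 100000 nM as a limit too. Compound 3 (`C#Cc1cccc(NC(=O)c2cc(NC(=O)CCCCCC(=O)NO)ccc2O)c1`) also gives only a limit, > 100000 nM once more, so it stands where every value shown stands. Compound 4 (`C#Cc1cccc(NC(=O)c2cc(NC(=O)CCCCCCC(=O)NO)ccc2O)c1`) carries (hydroxycarbamoyl)methyl in place of hydroxycarbamoyl on a saturated chain carbon, five bonds along the chain from a carbonyl carbon. The steps a step that the two limits leave unreadable from compound 1 to compound 2 and a step that the two limits leave unreadable from compound 1 to compound 3 and a step that the two limits leave unreadable from compound 2 to compound 3 all leave the chain untouched. Their sizes cannot be read because of the limit of > 100000 nM in this assay, at which 3 of the 3 values shown sit, and so give no guide to this change. No step beyond the scatter is therefore expected in this assay and no direction can be given. The estimate means an expected a number no higher from compound 3 to compound 4 (the limit leaves the size open) for this change. Compound 4 is estimated at 100000 nM (expected range 10000 nM to 300000 nM).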

Compound 4, half-maximal inhibitory concentration: > 100000 nM
Compound 4 gave a limit, no number; the forecaster's own chance of this, stated with the estimate: 70%; the middle value lies on the limit itself.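

Among these compounds, compound 4 again gives only a limit, so no step from compound 3 to compound 4 can be read: the limit of > 100000 nM in this assay, at which 4 of the 4 values shown sit. As far as these compounds go, whether the longer hydroxycarbamoyl chain changes activity at all, and in which direction, stays open.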